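Serine to Leucine Ester Swap on a Purine Scaffold

The compounds below may be only part of what the source reports. "The series", "measured", "known", "first", "only" and "open" are said of these compounds alone.

The series was examined in a functional assay on the whole organism (Tail, strain ICR) with Mus musculus as the target, in the tail flick test, with a stated time of 120 min, at a dose of 25 umol/kg by the oral route; a lower number here means a weaker effect, a higher number a stronger effect of the compound at the dose given. Compound 1, `O=C(CN(c1nc(Cl)nc2[nH]cnc12)C1CC1)N[C@@H](CO)C(=O)OCc1ccccc1`, gives 34.5% in this assay. Compound 3, `O=C(O)C[C@H](NC(=O)CN(c1nc(Cl)nc2[nH]cnc12)C1CC1)C(=O)O`, gives 22% in this assay. Compound 2, `O=C(CN(c1ncnc2c1ncn2C1CCCCO1)C1CC1)N[C@@H](CO)C(=O)OCc1ccccc1`, gives 29.2% in this assay; its number is separated from that of compound 1 and from that of compound 3 by less than the usual scatter, so the three compounds cannot be ranked against one another on these data.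

The unmeasured compound 4 is `CC(C)C[C@H](NC(=O)CN(c1ncnc2c1ncn2C1CCCCO1)C1CC1)C(=O)OCc1ccccc1`. It differs from compound 2 in a single place: isopropyl in place of hydroxy on a saturated chain carbon, two bonds along the chain from an amide-type nitrogen and a carbonyl carbon. Among the compounds with values here, no pair among the measured compounds shows this same change, so the data hold no step to copy for it. The three measured numbers all sit in a narrow band, and the author therefore expects no step beyond the scatter in either direction when going from compound 2 to compound 4; the step of a number 1.8 percentage points higher from compound 2 to compound 4 (within the scatter) is the size expected. On that basis compound 4 is estimated to give 31% in this assay, with an expected range from 16% to 46%.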

Compound 4, a percentage reported as activity, at one dose (the size of the read-out at that dose, not a potency): 12.8%
Compound 4: the middle estimate sits 18.2 percentage points above what was measured; measured number below the stated range.
By their numbers in this assay, from the lowest: compounds 4, 3, 2 and 1 (each within the scatter of the next, the first and the last beyond it).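

In this assay, within the data shown here, the change of hydroxy to isopropyl on a saturated chain carbon, two bonds along the chain from an amide-type nitrogen and a carbonyl carbon, gives the only step that can be read: a number 16.4 percentage points lower from compound 2 to compound 4 (beyond the scatter). The earlier compounds shown here formed no pair differing in one place, so they could not show that the read-out responds to this position; with the rest of compound 2 held constant, hydroxymethyl to isobutyl is enough to move the number beyond the scatter. Nothing available bears on why the number falls, and the hydrogen-bond donor and acceptor counted on hydroxy cannot be separated from the three carbons of isopropyl as the source of the step.

Going by these compounds, whether a small group such as methyl, a longer chain such as n-butyl, or an amine or a carboxylic acid at this carbon would give a number nearer that of compound 2 or of compound 4 remains open. On these data alone, it also remains open whether the same change would give a step of similar size on the core of compound 1.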